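A few compounds are considered here, and "the series" means these few. Any claim that something is new, unique, unknown or untested is made for them only; others in the source may bear on it.

In a functional assay on ZR-75-1 cells (Homo sapiens) for inhibition, read by sulforhodamine B assay; a lower number here means a stronger inhibitor of growth, a higher number a weaker inhibitor of growth:
- Compound 1 `Oc1cccc2[nH]c(-c3ccc(-c4ccc(-c5ccccc5)cc4)cc3)nc12`: 35600 nM
- Compound 2 `Oc1cccc2[nH]c(-c3ccc(-c4ccc(-c5ccc(C(F)(F)F)cc5)cc4)cc3)nc12`: 5110 nM
- Compound 3 `Oc1ccc(-c2ccc(-c3ccc(-c4nc5c(O)cccc5[nH]4)cc3)cc2)cc1`: 2650 nM

Compound 3 stands well clear of one neighbour, a 13-fold lower number from compound 1 to compound 3 (1.13 log units; beyond the scatter), but not of the other, a 1.9-fold lower number from compound 2 to compound 3 (0.29 log units; within the scatter). Compound 4 `COc1ccc(-c2ccc(-c3ccc(-c4nc5c(O)cccc5[nH]4)cc3)cc2)cc1OC` carries 3,4-dimethoxyphenyl in place of 4-hydroxyphenyl on an aromatic carbon, para to a large group: 3,4-dimethoxyphenyl in place of 4-hydroxyphenyl on an aromatic carbon. Among the measured compounds shown here, no measured step tests this exact change, so the evidence is indirect. Hydroxy gave the larger gain, yet compound 2 shows that a group without hydroxy also lowers the number, a 7.0-fold lower number from compound 1 to compound 2 (0.84 log units; beyond the scatter). In this assay, a small rise, probably not beyond the scatter, is therefore expected. The estimated step is a 1.7-fold higher number from compound 3 to compound 4 (0.23 log units; within the scatter). Compound 4 is expected at 4500 nM, with an estimated range of 1500 nM to 14000 nM.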

Compound 4, concentration for 50% growth inhibition: 2110 nM
For compound 4 the middle estimate is 2.1-fold (0.33 log units) above the measured one, within the range that was stated.
By their numbers in this assay, from the lowest: compounds 4, 3 and 2 (each within the scatter of the next, the first and the last beyond it); then compound 1.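

In this assay the change from 4-hydroxyphenyl to 3,4-dimethoxyphenyl gives a 1.3-fold lower number from compound 3 to compound 4 (0.10 log units; within the scatter) and so shows that this position tolerates a group with 0 hydrogen-bond donors without a step beyond the scatter. The same group, set against the other two groups at this position, gives a 17-fold lower number from compound 1 to compound 4 (1.23 log units; beyond the scatter) and a 2.4-fold lower number from compound 2 to compound 4 (0.38 log units; beyond the scatter) and thus extends the gain over phenyl to a third substituted ring. Nothing available explains these steps. Going by these compounds, it remains open whether a single methoxy would do the same, and how an amine or a carboxylic acid on this ring would behave.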